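Methoxy in place of hydrogen on the core of compound 2

This account rests on a few compounds, and the source may have more. Where it says the series, first, only, none or still open, it means among the compounds named here.

Compound 2 `O=c1c(Cc2coc3ccccc3c2=O)coc2ccccc12` sits at the limit of a functional assay on MDA-MB-231 cells (Homo sapiens) for antiproliferative activity, read by XTT assay; on this read-out higher numbers stand for weaker inhibition and lower numbers for stronger inhibition: in this assay compound 2 gives > 10000 nM, a limit and not a number. Compound 1 `O=c1c(Cc2coc3cccc(OCC4CCCCC4)c3c2=O)coc2ccccc12` gives 4110 nM in this assay. The step of an at least 2.4-fold higher number from compound 1 to compound 2 (0.38 log units; beyond the scatter) is bounded by the limit of > 10000 nM in this assay, at which 1 of the 2 values shown sits. Compound 3 `COc1cccc2occ(Cc3coc4ccccc4c3=O)c(=O)c12` carries methoxy in place of hydrogen on an aromatic carbon, the same aromatic carbon at which compound 1 bears cyclohexylmethoxy. Among the measured compounds shown here, only the step of an at least 2.4-fold higher number from compound 1 to compound 2 (0.38 log units; beyond the scatter) bears on this change, and with a smaller group entering, a downward step of at most that size is expected in this assay. Compound 3 is therefore estimated at 7000 nM, between 3000 nM and 15000 nM, an expected step of an at least 1.4-fold lower number from compound 2 to compound 3 (0.15 log units; that floor lies within the scatter).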

Compound 3, half-maximal inhibitory concentration: > 10000 nM
Compound 3 ended at the assay's limit (the forecaster's own chance of this, stated with the estimate: 40%); at least 1.4-fold (0.15 log units) between middle value and limit.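

Replacing cyclohexyl with hydrogen on the side chain gives an at least 2.4-fold higher number from compound 1 to compound 3 (0.38 log units; beyond the scatter) in this assay, so among the groups shown on this aromatic carbon, only cyclohexylmethoxy gives a value inside the range of this assay. Methoxy in place of hydrogen adds no readable gain, and compound 3 gives > 10000 nM, a limit and not a number. The step between compound 2 and compound 3 cannot be read, because both ends are limits: the limit of > 10000 nM in this assay, at which 2 of the 3 values shown sit.

From the compounds shown here alone, whether any effect of methoxy lies hidden beyond the limit stays open. Also open, going by these compounds, is whether a butoxy chain, a benzyloxy group or an amine on this aromatic carbon would give a value inside the range.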